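A Methyl Added to the Phenyl Ring of Compound 1

The compounds below may be only part of what the source reports. "The series", "measured", "known", "first", "only" and "open" are said of these compounds alone.

Measured in a functional assay on MDA-MB-231 cells (Homo sapiens) for inhibition, read by MTT assay, with a stated time of 72 h; a lower number here means a stronger inhibitor, a higher number a weaker inhibitor:
Compound 1 `CC1=NN(c2ccccc2)C(=O)[C@@]12C(=O)C=CC[C@H]2c1ccc(C)cc1`: 8300 nM
Compound 2 `CC1=NN(c2ccccc2)C(=O)[C@@]12C(=O)C=CC[C@@H]2c1ccc(C)cc1`: 7420 nM
Compound 3 `CC1=NN(c2ccccc2)C(=O)[C@@]12C(=O)C=CC[C@H]2c1ccccc1`: 5500 nM

Compound 1, at 8300 nM, stands close to both of its measured neighbours, and neither of its steps leaves the scatter. The next compound to be tested is compound 4 `CC1=NN(c2ccc(C)cc2)C(=O)[C@@]12C(=O)C=CC[C@H]2c1ccc(C)cc1`. It keeps the shared core of compound 1 and carries methyl in place of hydrogen on an aromatic carbon, so that phenyl becomes 4-methylphenyl (methyl in place of hydrogen on an aromatic carbon). The new methyl sits para to a large group.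

Two measured steps start from compound 1. One, a 1.1-fold lower number from compound 1 to compound 2 (0.05 log units; within the scatter), is a change of configuration only and touches no aromatic ring, so it bears little on this question. The other, a 1.5-fold lower number from compound 1 to compound 3 (0.18 log units; within the scatter), is hydrogen in place of methyl on an aromatic carbon. Within the data shown here, it is the closest precedent, although it lies on a different ring from the new methyl and runs the opposite way, from methyl to hydrogen. Since that step stayed within the scatter, no step beyond the scatter is expected in this assay for the new methyl. The expected change is a 1.0-fold lower number from compound 1 to compound 4 (0.02 log units; within the scatter). For compound 4 the estimated value is 8000 nM, with an expected range from 3800 nM to 17000 nM.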

Compound 4, half-maximal inhibitory concentration: 9200 nM
For compound 4 the middle estimate is 1.2-fold (0.06 log units) below the measured one; the range from low to high includes it.
By their numbers in this assay, from the lowest: compounds 3, 2, 1 and 4 (each within the scatter of the next).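

In this assay, the change from phenyl to 4-methylphenyl gives a 1.1-fold higher number from compound 1 to compound 4 (0.04 log units; within the scatter), the first measured step at this position among the compounds shown. Among these compounds, until now, the only measured change of this kind lay on the other aromatic ring and ran from methyl to hydrogen, as a 1.5-fold lower number from compound 1 to compound 3 (0.18 log units; within the scatter); the new result shows that a methyl placed on this ring, para to a large group, also leaves the number within the scatter, so that a single methyl on either ring has yet to produce a step that can be told from repeated measurement. Among the compounds shown here, nothing at hand bears on why this step is so small, and the single step gives no cause for it.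

The compounds shown leave open whether a group other than methyl at this same place, such as an amine, a carboxylic acid or a longer chain like butyl, would move the number beyond the scatter. They also leave open whether 4-methylphenyl would give a similar step on the configuration drawn in compound 2.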